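Swapping a silyl ether for an acetate on the shared core

This account rests on a few compounds, and the source may have more. Where it says the series, first, only, none or still open, it means among the compounds named here.

Compound 1 `C=C1CC[C@@H]2[C@](C)(CO[Si](C(C)C)(C(C)C)C(C)C)[C@H](O)CC[C@@]2(C)[C@@H]1C/C=C1/C(=O)OC[C@H]1O` gives the lowest number of the three measured compounds in a functional assay on KB cells (Homo sapiens) for cytotoxicity, read by sulforhodamine B assay (a higher number here means that more compound is needed for the effect, a lower number that less compound is needed), at 2.73 uM. Compound 2 `C=C1CC[C@@H]2[C@](C)(CO[Si](c3ccccc3)(c3ccccc3)C(C)(C)C)[C@H](O)CC[C@@]2(C)[C@@H]1C/C=C1/C(=O)OC[C@H]1O` gives 11.1 uM in this assay, and compound 3 `C=C1CC[C@@H]2[C@](C)(CO[Si](c3ccccc3)(c3ccccc3)C(C)(C)C)[C@H](O)CC[C@@]2(C)[C@@H]1C/C=C1/C(=O)OC[C@H]1OC(C)=O` gives 10.5 uM; the gap from compound 1 to either one lies beyond the scatter. Among the compounds with values here, the single step measured in one place, a 1.1-fold lower number from compound 2 to compound 3 (0.02 log units; within the scatter), concerns an oxygen other than the one changed here. Compound 4 `C=C1CC[C@@H]2[C@](C)(COC(C)=O)[C@H](O)CC[C@@]2(C)[C@@H]1C/C=C1/C(=O)OC[C@H]1O` differs from compound 1 by a group of 3 heavy atoms (2 carbon, 1 oxygen; no ring) in place of a group of 10 heavy atoms (9 carbon, 1 silicon; no ring), on an oxygen on a saturated carbon. Within the data shown here, no measured step matches this change; compound 1 and compound 2, which differ at that same oxygen, give numbers beyond the scatter of each other, so a shift is possible but its direction is open. Compound 4 is expected to give about 4 uM (range 1.5 uM to 12 uM), an expected step of a 1.5-fold higher number from compound 1 to compound 4 (0.17 log units; within the scatter).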

Compound 4, concentration for half-maximal effect: 15.3 uM
Estimate against measurement, compound 4: 3.8-fold (0.58 log units) below, outside the stated range (above it).
By their numbers in this assay, from the lowest: compound 1; then compounds 3, 2 and 4 (each within the scatter of the next).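

At this oxygen, acetyl in place of the group of 10 heavy atoms in compound 1 moves this assay upward, with a 5.6-fold higher number from compound 1 to compound 4 (0.75 log units; beyond the scatter), so the direction left open earlier is now settled for this pair. Compound 4 lies within the scatter of compound 2, so of the three groups shown on this oxygen, only that of compound 1 stands apart. Nothing shown gives a reason for this shift.

On these data alone, whether a free hydroxyl or a longer acyl chain, such as hexanoyl, on this oxygen would stand with compound 1 or with compound 4 remains open.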